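The compounds below may be only part of what the source reports. "The series", "measured", "known", "first", "only" and "open" are said of these compounds alone.

Measured in a functional assay on MCF7 cells (Homo sapiens) for inhibition, read by sulforhodamine B assay, with a stated time of 48 h; a lower number here means a stronger inhibitor of growth, a higher number a weaker inhibitor of growth:

Compound 1 `c1ccc2cc(NC3=NCCO3)ccc2c1`: 4500 nM
Compound 2 `O=C(CCl)NC(=O)Nc1ccc(-c2ccccc2)cc1`: 3900 nM

In this assay, compound 2 gives 3900 nM, and this value lies within the usual scatter of compound 1, so the two cannot be told apart. Compound 3 `O=C(CCl)NC(=O)Nc1ccc(OC2CCCCC2)cc1` has not yet been measured. It is made from compound 2 by one change, with cyclohexyloxy in place of phenyl on an aromatic carbon. The rest of the molecule stays the same. For the measured compounds named here, no two measured compounds differ in only one place, so no measured step shows what such a swap does. The expectation therefore rests on compound 2 at 3900 nM, and no change beyond the scatter is expected in this assay. The expected step is a 1.3-fold lower number from compound 2 to compound 3 (0.11 log units; within the scatter). For compound 3 the estimated value is 3000 nM, with an expected range of 1000 nM to 9000 nM.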

Compound 3, concentration for 50% growth inhibition: 4700 nM
Beside the measured number, compound 3's estimate is 1.6-fold (0.19 log units) below it; the measured number falls inside the stated range.
By their numbers in this assay, from the lowest: compounds 2, 1 and 3 (each within the scatter of the next).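

In this assay, for the compounds shown here, putting cyclohexyloxy in place of phenyl on the aromatic carbon para to a group of 8 heavy atoms gives a 1.2-fold higher number from compound 2 to compound 3 (0.08 log units; within the scatter) and so provides the first measured step between two compounds that differ in one place. On this single step, an aromatic ring of carbon only and a non-aromatic ring of carbon only attached through an oxygen cannot be told apart at this position, even though the entering group brings a hydrogen-bond acceptor that the leaving group lacks. No measurement at hand offers an explanation for this result.

From the compounds shown here alone, whether any group at this position can shift growth inhibition beyond the scatter remains open. An amine, a carboxylic acid or a longer chain in this place could answer that, and this single pair cannot predict their effect.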